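A few compounds are considered here, and "the series" means these few. Any claim that something is new, unique, unknown or untested is made for them only; others in the source may bear on it.

Measured in an ADME assay on the whole organism (Rattus norvegicus) for pharmacokinetics; on this read-out higher numbers stand for higher oral bioavailability and lower numbers for lower oral bioavailability:
- compound 1 `CN(c1ccn(C)n1)c1cnc(NCc2c(F)ccc3c2CCO3)n2cnnc12`: 67%
- compound 2 `CNC(=O)c1ccc(-c2cnc(NCc3c(F)ccc4c3CCO4)c3cn[nH]c(=O)c23)c(C)n1`: 53%

Compound 1, at 67%, holds the higher of the two numbers, and the gap down to compound 2 at 53% lies beyond the usual scatter. Compound 3 `O=C1CC2(CC2)CN1c1cnc(NCc2c(F)ccc3c2CCO3)n2cnnc12` keeps the core of compound 1 but exchanges one group on an aromatic carbon: methyl(1-methyl-1H-pyrazol-3-yl)amino leaves and a group with no common name enters (a group of 8 heavy atoms (6 carbon, 1 nitrogen, 1 oxygen; one three-membered non-aromatic ring of carbon only, one five-membered non-aromatic ring with 1 hetero atom) in place of a group of 8 heavy atoms (5 carbon, 3 nitrogen; one five-membered aromatic ring with 2 hetero atoms), on an aromatic carbon). For the measured compounds named here, no measured pair shows what such an exchange does in this assay, so any forecast is loose. Since compound 1 already holds the higher number, 67%, a small fall within the scatter is the likeliest outcome. The expected step is a number 9 percentage points lower from compound 1 to compound 3 (within the scatter). Compound 3 is estimated at 58%, with an expected range of 35% to 80%.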

Compound 3, oral bioavailability: 68%
Beside the measured number, compound 3's estimate is 10 percentage points below it, within the range that was stated.
By their numbers in this assay, from the lowest: compound 2; then compounds 1 and 3 (each within the scatter of the next).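

In this assay, the exchange on this aromatic carbon gives a number 1 percentage points higher from compound 1 to compound 3 (within the scatter), so the methyl(1-methyl-1H-pyrazol-3-yl)amino group and its five-membered aromatic ring are not required at this position to hold the read-out at the level of compound 1. A group with a three-membered carbon ring and a five-membered non-aromatic ring, with 1 hydrogen-bond acceptor in place of 3, is accepted here, although the two groups match in little beyond their 8 heavy atoms. Nothing available explains why the two groups read alike.

The compounds shown leave open whether a different group on this carbon, such as dimethylamino or a morpholine ring, would read the same way. They also do not separate the contribution of the three-membered ring from that of the five-membered ring that carries it.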